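This account rests on a few compounds, and the source may have more. Where it says the series, first, only, none or still open, it means among the compounds named here.

Of the compounds shown here, three sharing one core have been tested in an assay on isolated protein for inhibition of Rho-associated protein kinase 2 (Homo sapiens), read by scintillation counting, radiometric assay and 33P incorporation, with a stated time of 40 min, in the presence of a further agent that is not named here; a lower number here means a stronger inhibitor, a higher number a weaker inhibitor. Compound 1 `CC(=O)Nc1cccc(NC(=O)COc2ccc3c(=O)ccoc3c2)c1` gives 136 nM. Compound 2 `Cc1ccc(C(=O)Nc2cccc(NC(=O)COc3ccc4c(=O)ccoc4c3)c2)cc1` gives 22 nM, and compound 3 `O=C(COc1ccc2c(=O)ccoc2c1)Nc1cccc(NC(=O)c2ccc([N+](=O)[O-])cc2)c1` gives 15 nM. Replacing the methyl on the carbonyl carbon with an aryl group brought the larger shifts: a 6.2-fold lower number from compound 1 to compound 2 (0.79 log units; beyond the scatter) and a 9.1-fold lower number from compound 1 to compound 3 (0.96 log units; beyond the scatter). Swapping one group for another on that aryl ring did little: a 1.5-fold lower number from compound 2 to compound 3 (0.17 log units; within the scatter). Compound 3 therefore holds the lowest of the three numbers, with compound 2 close behind it within the scatter and compound 1 furthest away.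

Compound 4 `O=C(COc1ccc2c(=O)ccoc2c1)Nc1cccc(NC(=O)c2ccc(C(=O)O)cc2)c1` is the next candidate. It differs from compound 3 by carboxy in place of nitro on an aromatic carbon. Within the data shown here, the only measured step at this same place, between compound 2 and compound 3, stayed within the scatter, so a change on this aromatic carbon has so far mattered little, and the step expected here is a 2.0-fold higher number from compound 3 to compound 4 (0.30 log units; within the scatter), likely also within the scatter. Compound 4 is thus expected to give 30 nM, with a plausible range from 10 nM to 90 nM.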

Compound 4, half-maximal inhibitory concentration: 2030 nM
For compound 4 the middle estimate is 68-fold (1.83 log units) below the measured one, outside the stated range (above it).
By their numbers in this assay, from the lowest: compounds 3 and 2 (each within the scatter of the next); then compound 1; then compound 4.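

On this aromatic carbon the choice of group can matter a great deal, although nitro and methyl stayed within the scatter of each other: carboxy in place of nitro gives a 140-fold higher number from compound 3 to compound 4 (2.13 log units; beyond the scatter) and carboxy in place of methyl gives a 92-fold higher number from compound 2 to compound 4 (1.97 log units; beyond the scatter) on the same ring. An aryl group on the carbonyl carbon therefore does not lower the number by itself, since 4-carboxyphenyl in place of methyl gives a 15-fold higher number from compound 1 to compound 4 (1.17 log units; beyond the scatter) in the opposite direction to the other two aryl groups. Nothing available explains why carboxy differs so sharply from nitro, even though both have the same count of heavy atoms.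

On these data alone, it remains open whether the loss follows the whole carboxy group or only its hydrogen-bond donor. A methyl ester or a primary amide on this same aromatic carbon would help separate those two readings.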